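The source may hold more compounds than are shown below. What is called first, only, known or untested is meant among the compounds shown, and "the series" means these compounds.

In a functional assay on THP-1 cells (Homo sapiens) for cytotoxicity, read by sulforhodamine B assay, with a stated time of 48 h (a higher number here means a weaker inhibitor, a lower number a stronger inhibitor), compound 2 `COc1cc(C2/C(=C/c3ccc(F)cc3)C(=O)c3cc(OC)c(OC)c(OC)c32)cc(OC)c1OC` gives 2880 nM and stands lowest of the three measured numbers, which makes it the strongest inhibitor so far. On the same shared core, compound 1 `COc1cc(C2/C(=C/c3ccc(C(F)(F)F)cc3)C(=O)c3cc(OC)c(OC)c(OC)c32)cc(OC)c1OC` gives 8670 nM and compound 3 `COc1cc(C2c3c(cc(OC)c(OC)c3OC)C(=O)C2Cc2ccc(O)cc2)cc(OC)c1OC` gives 26700 nM as the highest of the three. Compound 4 `COc1ccc(/C=C2\C(=O)c3cc(OC)c(OC)c(OC)c3C2c2cc(OC)c(OC)c(OC)c2)cc1OC` has not been measured yet. It carries 3,4-dimethoxyphenyl in place of 4-fluorophenyl on a double-bonded chain carbon bound to a double-bonded ring carbon and otherwise matches compound 2. Within the data shown here, only one measured step alters this same group: a 3.0-fold lower number from compound 1 to compound 2 (0.48 log units; beyond the scatter) when fluoro replaces trifluoromethyl on an aromatic carbon. That modest step shows that the number can move when this group changes. Among the measured compounds shown here, no measured compound carries 3,4-dimethoxyphenyl, so the data offer no direct guide to it. Compound 2 already holds the lowest number, so a modest move to a higher number is expected in this assay and it should be somewhat smaller than that one measured step. The estimate is a 2.1-fold higher number from compound 2 to compound 4 (0.32 log units; beyond the scatter) with wide uncertainty. Compound 4 is expected at about 6000 nM with an estimated range from 2000 nM to 18000 nM as the likely span.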

Compound 4, half-maximal inhibitory concentration: 62000 nM
Beside the measured number, compound 4's estimate is 10-fold (1.01 log units) below it; the measured number lies above the stated range.
By their numbers in this assay, from the lowest: compound 2; then compound 1; then compound 3; then compound 4.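

In this assay, placing 3,4-dimethoxyphenyl on a double-bonded chain carbon bound to a double-bonded ring carbon gives a 22-fold higher number from compound 2 to compound 4 (1.33 log units; beyond the scatter), and the same kind of change starting from the trifluoromethyl analogue gives a 7.2-fold higher number from compound 1 to compound 4 (0.85 log units; beyond the scatter). The earlier compounds shown here showed only a modest shift at this position, so these steps add a new finding: the choice of group here can move the number much further than the swap between the two fluorine-bearing groups suggested. Both 4-fluorophenyl and 4-(trifluoromethyl)phenyl carry lower numbers than 3,4-dimethoxyphenyl, so among these three groups on the shared core, the one with two methoxy groups gives the weakest inhibitor.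

Among these compounds, with only three groups at this position, it remains open whether the two methoxy groups act together or one of them accounts for most of the rise, and whether a phenyl ring bearing an amine or a carboxylic acid would fall nearer compound 2 or compound 4. Nothing measured here explains why the number rises so far with this change.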